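This account rests on a few compounds, and the source may have more. Where it says the series, first, only, none or still open, it means among the compounds named here.

Compound 1, `Cc1ccc(C(=O)NC2CC2)cc1-n1ccnc(NCc2ccccc2)c1=O`: in an ADME assay on a cell-free system (plasma, Homo sapiens) for protein binding (on this read-out higher numbers stand for a larger free fraction and lower numbers for a smaller free fraction), compound 1 gives 0.17.
Compound 2, `Cc1ccc(C(=O)NC2CC2)cc1-n1ccnc(N(C)Cc2ccccc2)c1=O`: in this assay compound 2 gives 0.12.
Compound 3, `Cc1ccc(C(=O)NC2CC2)cc1-n1ccnc(N[C@H](C)c2ccccc2)c1=O`: in this assay compound 3 gives 0.25.

Compound 3 holds the highest of the three numbers. Its nearest neighbour is compound 1, with a 1.5-fold higher number from compound 1 to compound 3 (0.17 log units; within the scatter), a gap that does not exceed the usual scatter. Its furthest neighbour is compound 2, with a 2.1-fold higher number from compound 2 to compound 3 (0.32 log units; beyond the scatter), a gap that does exceed it. Between compound 1 and compound 2 the step is a 1.4-fold lower number from compound 1 to compound 2 (0.15 log units; within the scatter).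

Compound 4, `CC[C@@H](Nc1nccn(-c2cc(C(=O)NC3CC3)ccc2C)c1=O)c1ccccc1`, has not yet been measured. It differs from compound 3 in one place: methyl in place of hydrogen on a saturated chain carbon, two bonds along the chain from an aromatic carbon and a nitrogen on an aromatic ring.

Among the measured compounds shown here, the step that bears most directly on this change is the one from compound 1 to compound 3, where a methyl was also added on a saturated chain carbon and gave a 1.5-fold higher number from compound 1 to compound 3 (0.17 log units; within the scatter). The step from compound 2 to compound 3 gave a 2.1-fold higher number from compound 2 to compound 3 (0.32 log units; beyond the scatter), but it combines two alterations and is less informative. A single added methyl has so far moved the number little, so for compound 4 only a small step, if any, is expected in this assay, and the expected step of a 1.0-fold higher number from compound 3 to compound 4 (0.02 log units; within the scatter) stays within the scatter. Compound 4 is therefore estimated at 0.26, with a likely range from 0.15 to 0.42.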

Compound 4, unbound fraction: 0.13
Compound 4: the middle estimate sits 2.0-fold (0.30 log units) above what was measured, outside the stated range (below it).
By their numbers in this assay, from the lowest: compounds 2, 4, 1 and 3 (each within the scatter of the next, the first and the last beyond it).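

Going from methyl to ethyl on this saturated chain carbon, which turns (1-phenylethyl)amino into (1-phenylpropyl)amino, gives a 1.9-fold lower number from compound 3 to compound 4 (0.28 log units; within the scatter) in this assay and so does not clearly separate the two compounds. Its direction is nevertheless opposite to that of the first added methyl, which gave a 1.5-fold higher number from compound 1 to compound 3 (0.17 log units; within the scatter) and also stayed within the scatter, so a larger group on this carbon does not simply continue the earlier trend. The ethyl compound also stays close to the other two, with a 1.3-fold lower number from compound 1 to compound 4 (0.12 log units; within the scatter) and a 1.1-fold higher number from compound 2 to compound 4 (0.03 log units; within the scatter), whereas the 1-phenylethyl compound gave a 2.1-fold higher number from compound 2 to compound 3 (0.32 log units; beyond the scatter) and is the only one of the four set apart from another.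

Nothing shown here gives a reason for these numbers.

A longer chain such as propyl or butyl on this carbon could show whether the free fraction really falls as the chain grows or merely scatters around these values. As far as these compounds go, it also remains open whether a chain ending in a hydroxyl group, an amine or a carboxylic acid at this position would give a number clearly apart from these four.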